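The source may hold more compounds than are shown below. What is called first, only, known or untested is meant among the compounds shown, and "the series" means these compounds.

Measured compounds:
compound 1 `C=C1C[C@]23C[C@@]1(O)CC[C@H]2c1cc(Br)c(O)c(C)c1[C@@H]3Cn1cc(-c2ccc(F)cc2)nn1`, which in a functional assay on A549 cells (Homo sapiens) for cytotoxicity, read by MTT assay, with a stated time of 4 days (a lower number here means a stronger inhibitor, a higher number a weaker inhibitor), gives 17900 nM;
compound 2 `C=C1C[C@]23C[C@@]1(O)CC[C@H]2c1ccc(O)c(C)c1[C@@H]3Cn1cc(-c2ccc(F)cc2)nn1`, which in this assay gives > 20000 nM, a limit of the assay rather than a number;
compound 3 `C=C1C[C@]23C[C@@]1(O)CC[C@@H]2c1cccc(C)c1[C@@H]3Cn1cc(-c2ccc(C)cc2)nn1`, which in this assay gives > 20000 nM, again a limit of the assay.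

Within the data shown here, compound 1 therefore stands as the only compound of the three with a number in this assay; the other two values sit at a limit (the limit of > 20000 nM in this assay, at which 2 of the 3 values shown sit). Among the measured compounds shown here, the one measured step, an at least 1.1-fold higher number from compound 1 to compound 2 (0.04 log units; that floor lies within the scatter), hydrogen in place of bromo on an aromatic carbon, reaches only a limit and its floor lies within the scatter.

Compound 4 `C=C1C[C@]23C[C@@]1(O)CC[C@H]2c1cc(Br)c(O)c(C)c1[C@@H]3Cn1cc(-c2ccc(Cl)cc2)nn1` differs from compound 1 by chloro in place of fluoro on an aromatic carbon. For the measured compounds named here, no measured step touches this change, and the single step measured concerns another place in the molecule, so the data give no direction for it. The expected step in this assay is a 1.2-fold lower number from compound 1 to compound 4 (0.08 log units; within the scatter), which lies within the scatter. Compound 4 is therefore estimated at 15000 nM, in the range 6000 nM to 40000 nM.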

Compound 4, half-maximal inhibitory concentration: 10500 nM
For compound 4 the middle estimate is 1.4-fold (0.15 log units) above the measured one; the range from low to high includes it.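

Among these compounds, the change from 4-fluorophenyl to 4-chlorophenyl is the first measured at this position, and in this assay it gives a 1.7-fold lower number from compound 1 to compound 4 (0.23 log units; within the scatter). Fluoro and chloro at this position therefore cannot be told apart here, and the data give this change no direction. Compound 2 and compound 3 remain at a limit of the assay, which leaves only compound 1 and compound 4 with numbers: the limit of > 20000 nM in this assay, at which 2 of the 4 values shown sit.

On these data alone, it remains open whether another group at this position, such as an amine, a carboxylic acid or a longer chain, would shift the number beyond the scatter. Among the compounds shown here, the role of the bromo group also remains open, as the one step that touches it reaches only a limit and cannot be read.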